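The source may report more compounds than this note shows. Statements on the series, on what has been measured and on what is new or still open speak of the compounds shown alone.

Measured compounds:
Compound 1, `Cc1ccc(Nc2ncc(C(F)(F)F)c(N3Cc4cccc(N(C)S(C)(=O)=O)c4C3)n2)c(Cl)c1`: > 30000 nM, a limit of the assay.
Compound 2, `COc1cc(Nc2ncc(C(F)(F)F)c(N3Cc4cccc(N(C)S(C)(=O)=O)c4C3)n2)cc(OC)c1`: 630 nM.
Compound 3, `Cc1ccc(Nc2ncc(C(F)(F)F)c(N3Cc4cccc(N(C)S(C)(=O)=O)c4C3)n2)c(C)c1`: > 30000 nM, a limit of the assay.

The read-out throughout is a functional assay on OVCAR-3 cells (Homo sapiens) for antiproliferative activity, read by spectrophotometry, with a stated time of 2 days; on this read-out higher numbers stand for weaker inhibition of growth and lower numbers for stronger inhibition of growth. Compound 1 stands at the limit of > 30000 nM in this assay, at which 2 of the 3 values shown sit, so for it only a limit is known and no number. Within the data shown here, compound 3 sits at that same limit; compound 2 is the single numbered value among the three. The compound still to be run is compound 4, `CN(c1cccc2c1CN(c1nc(Nc3cc(Cl)cc(C(F)(F)F)c3)ncc1C(F)(F)F)C2)S(C)(=O)=O`. Against compound 1 it shows (3-chloro-5-(trifluoromethyl)phenyl in place of 2-chloro-4-methylphenyl on a nitrogen on an aromatic ring).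

Among the measured compounds shown here, two measured steps bear on this change, both at the same nitrogen: an at least 47-fold lower number from compound 1 to compound 2 (1.67 log units; beyond the scatter) and an at least 47-fold higher number from compound 2 to compound 3 (1.67 log units; beyond the scatter). The direct comparison is a step that the two limits leave unreadable from compound 1 to compound 3. Within these three, both aryl groups substituted at the 2- and 4-positions sit at the limit, and the one substituted at the 3- and 5-positions does not. For the measured compounds named here, compound 4 carries the 3,5-substitution pattern, but with chloro and trifluoromethyl where compound 2 has two methoxy groups; no measured step covers that exchange, so the expectation leans on the ring pattern alone. Compound 4 is therefore expected to move by an at least 10-fold lower number from compound 1 to compound 4 (1.00 log units; beyond the scatter), towards a stronger read-out than compound 1. The estimate for compound 4 is 3000 nM, expected between 400 nM and 30000 nM.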

Compound 4, concentration for 50% growth inhibition: 21500 nM
Compound 4: the middle estimate sits 7.2-fold (0.86 log units) below what was measured; the measured number falls inside the stated range.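

The aryl group on this nitrogen is not settled by the placing of its substituents alone: 3-chloro-5-(trifluoromethyl)phenyl in place of 3,5-dimethoxyphenyl gives a 34-fold higher number from compound 2 to compound 4 (1.53 log units; beyond the scatter), so the identity of the two substituents counts as well. Against the other two aryl groups the same compound gives an at least 1.3-fold lower number from compound 1 to compound 4 (0.14 log units; that floor lies within the scatter) and an at least 1.3-fold lower number from compound 3 to compound 4 (0.14 log units; that floor lies within the scatter); each floor lies within the scatter, so no gain over either is established. The values of compound 1 and compound 3 are limits of the assay and not numbers, so these two steps have no upper size and the step between the two compounds cannot be read: the limit of > 30000 nM in this assay, at which 2 of the 4 values shown sit.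

Open, from the compounds shown here alone, is whether the two methoxy groups of compound 2 are both needed, and whether a single methoxy group, a hydroxyl, an amine or a carboxylic acid on that aryl group would hold the activity of compound 2 at 630 nM. Also open, going by these compounds, is how far this aryl trend carries once the methanesulfonamide on the shared core gives way to another group, such as an acetamide.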